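The source may hold more compounds than are shown below. What is called first, only, known or untested is meant among the compounds shown, and "the series" means these compounds.

The three measured compounds, with their results in an ADME assay on the whole organism for cytotoxicity, with Artemia salina as the target, with a stated time of 24 h; on this read-out lower numbers stand for an effect already at smaller amounts and higher numbers for an effect only at larger amounts of compound:

Compound 1, `Cc1ccc(S(=O)(=O)NC(=O)Nc2ccccc2C(=O)/C=C/c2ccccc2O)cc1`: 32.3 ug/mL
Compound 2, `Cc1ccc(S(=O)(=O)NC(=O)Nc2ccccc2C(=O)/C=C/c2cccc(O)c2)cc1`: 39.3 ug/mL
Compound 3, `CCOc1cc(/C=C/C(=O)c2ccccc2NC(=O)NS(=O)(=O)c2ccc(C)cc2)ccc1O`: 19.2 ug/mL

Compound 3 has the smallest number of the three. The step of a 1.7-fold lower number from compound 1 to compound 3 (0.23 log units; within the scatter) lies within the scatter, so those two cannot be told apart; the step of a 2.0-fold lower number from compound 2 to compound 3 (0.31 log units; beyond the scatter) lies beyond it, and the step of a 1.2-fold higher number from compound 1 to compound 2 (0.09 log units; within the scatter) separates compounds 1 and 2 only within the scatter. All three differ solely in the substitution pattern of the phenyl ring at the end of the double-bonded chain.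

Compound 4, `COc1cc(/C=C/C(=O)c2ccccc2NC(=O)NS(=O)(=O)c2ccc(C)cc2)ccc1O`, differs from compound 3 by hydrogen in place of methyl on a saturated chain carbon bound to an oxygen on an aromatic ring. For the measured compounds named here, none of the measured steps touches this part of the molecule: each of them exchanges one hydroxyphenyl pattern for another, and even those larger swaps moved the numbers only modestly. A change of a single carbon on the ethoxy group is smaller than any of them, so the expectation for compound 4 is a step of about a 1.0-fold higher number from compound 3 to compound 4 (0.02 log units; within the scatter), that is, no change beyond the scatter. Compound 4 is therefore estimated at 20 ug/mL, with a plausible range from 10 ug/mL to 40 ug/mL.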

Compound 4, concentration for half-maximal effect: 17.8 ug/mL
Beside the measured number, compound 4's estimate is 1.1-fold (0.05 log units) above it; the range from low to high includes it.
By their numbers in this assay, from the lowest: compounds 4, 3, 1 and 2 (each within the scatter of the next, the first and the last beyond it).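

In this assay, the first change made at this position, ethyl to methyl on the oxygen of the aromatic ring, gives a 1.1-fold lower number from compound 3 to compound 4 (0.03 log units; within the scatter), so removing this one carbon leaves the result within the scatter. The 4-hydroxy-3-methoxyphenyl group also stands against the two simpler hydroxyphenyl groups much as the 3-ethoxy-4-hydroxyphenyl group does: there is a 2.2-fold lower number from compound 2 to compound 4 (0.34 log units; beyond the scatter), while a 1.8-fold lower number from compound 1 to compound 4 (0.26 log units; within the scatter), the same split into one step beyond the scatter and one within it that compound 3 showed. No measurement here offers an explanation for why the two alkoxy groups cannot be told apart in this assay.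

Going by these compounds, with only methoxy and ethoxy at this oxygen, it remains open whether a longer chain such as butyl, or a chain ending in a carboxylic acid or an amine, would also leave the number within the scatter. Also open, on these data alone, is what would happen if the whole alkoxy group gave way to hydrogen, leaving a plain 4-hydroxyphenyl group, which would show whether the group matters at all in this assay.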